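A few compounds are considered here, and "the series" means these few. Any claim that something is new, unique, unknown or untested is made for them only; others in the source may bear on it.

Series notes. The shared core appears in compound 1 `BrC12CCCC3CC(CCC31)C2`, in the methyl ester compound 2 `COC(=O)C12CCCC3CC(CCC31)C2` and in the octyl ester compound 3 `CCCCCCCCOC(=O)C12CCCC3CC(CCC31)C2`. In an ADME assay (Gallus gallus) for cytotoxicity, read by microscopy, with a stated time of 24 h (a lower number here means that less compound is tolerated, a higher number that more compound is tolerated), compound 1 gives no result reported. In this assay compound 2 gives 80000 nM, the lowest of the two numbers available; in this assay compound 3 gives 490000 nM. Among the compounds with values here, the one measured step, a 6.1-fold higher number from compound 2 to compound 3 (0.79 log units; beyond the scatter), comes from heptyl in place of hydrogen on a saturated chain carbon bound to an oxygen next to a carbonyl group.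

Compound 4 `CCCCNC(=O)C12CCCC3CC(CCC31)C2` is the butylamide. Compared with compound 2 it differs by butylamino in place of methoxy on a carbonyl carbon. Within the data shown here, no measured step changes the ester into an amide, so the step from compound 2 to compound 3 bears only loosely, as an indication that enlarging the group on the carbonyl carbon went with a higher number. A small rise is therefore expected, a 1.5-fold higher number from compound 2 to compound 4 (0.18 log units; within the scatter), not certainly beyond the scatter. In this assay compound 4 is estimated at 120000 nM, within 40000 nM to 400000 nM.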

Compound 4, minimum cytotoxic concentration: 300000 nM
Compound 4: the middle estimate sits 2.5-fold (0.40 log units) below what was measured; the measured number falls inside the stated range.
By their numbers in this assay, from the lowest: compound 2; then compounds 4 and 3 (each within the scatter of the next).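

In this assay, butylamino in place of methoxy on a carbonyl carbon gives a 3.8-fold higher number from compound 2 to compound 4 (0.57 log units; beyond the scatter), so a change of the atom bound to the carbonyl carbon, not only a longer chain on the ester oxygen, goes with a higher number. Within the data shown here, this second change moves the same way as a 6.1-fold higher number from compound 2 to compound 3 (0.79 log units; beyond the scatter), leaving the methyl ester compound 2 with the lowest number so far, while compound 4 and compound 3 lie within the scatter of each other. No measurement at hand accounts for the rise.

The compounds shown do not separate the contribution of the amide nitrogen from that of the butyl chain. A methylamino group or a carboxylic acid on the same carbonyl carbon would bear on that question.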